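Removing a methoxy group from a coumarin-triazole-linked dienone

A few compounds are considered here, and "the series" means these few. Any claim that something is new, unique, unknown or untested is made for them only; others in the source may bear on it.

Three compounds with a shared core, a coumarin joined through a triazole to a dienone, have been tested in a functional assay on THP-1 cells (Homo sapiens) for inhibition, read by sulforhodamine B assay, with a stated time of 48 h, tested at 50 uM; a higher number here means more inhibition of growth at the concentration tested, a lower number less inhibition of growth. Compound 1 `COc1ccccc1/C=C/C(=O)/C=C/c1ccc(OCc2cn(CCCOc3cc(=O)oc4ccccc34)nn2)c(OC)c1` gives 50%, compound 3 `COc1ccccc1/C=C/C(=O)/C=C/c1ccc(OCc2cn(CCCCOc3cc(=O)oc4ccccc34)nn2)c(OC)c1` gives 40%, and compound 2 `COc1ccc(/C=C/C(=O)/C=C/c2ccc(OCc3cn(CCCCCOc4cc(=O)oc5ccccc45)nn3)c(OC)c2)cc1` gives 39%. Compound 2 has the lowest of the three numbers; it sits within the scatter of compound 3 but lies beyond the scatter below compound 1. Compound 4 `COc1cc(/C=C/C(=O)/C=C/c2ccccc2)ccc1OCc1cn(CCCCCOc2cc(=O)oc3ccccc23)nn1` differs from compound 2 in one place: hydrogen in place of methoxy on an aromatic carbon. For the measured compounds named here, no measured pair shows this change, so the step from compound 2 to compound 4 in this assay is expected to be small, in no clear direction, likely within the scatter. Compound 4 is estimated at 42%, in a range from 25% to 60%, an expected step of a number 3 percentage points higher from compound 2 to compound 4 (within the scatter).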

Compound 4, percent growth inhibition at one concentration: 26%
Estimate against measurement, compound 4: 16 percentage points above; low and high end bracket the measured number.
By their numbers in this assay, from the lowest: compound 4; then compounds 2, 3 and 1 (each within the scatter of the next, the first and the last beyond it).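

In this assay, replacing the methoxy group with hydrogen, which turns 4-methoxyphenyl into phenyl, gives a number 13 percentage points lower from compound 2 to compound 4 (beyond the scatter) on this single change. For the compounds shown here, this is the first direct reading at this position, and it shows that the methoxy group on that ring is not a neutral part of compound 2 here. No measurement at hand explains the drop.

As far as these compounds go, whether an amine, a hydroxyl group or a fluorine atom at this place would restore the number remains open. So does whether the step would repeat with a longer chain.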